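Furan-thienopyrimidine series: ring amine swap at the chain carbon

The source may report more compounds than this note shows. Statements on the series, on what has been measured and on what is new or still open speak of the compounds shown alone.

Compound 1 `Nc1nc(-c2ccco2)nc2sc(CNC3CCCCC3)cc12` has the higher of the two numbers in hand: in an assay on CHO-K1 cells for antagonist activity at adenosine receptor A1 (Homo sapiens), read by a beta-galactosidase reporter, with stated times of 15 min and 6 h (a higher number here means a weaker inhibitor, a lower number a stronger inhibitor), compound 1 gives 2480 nM. Compound 2 `Cc1ccc(-c2nc(N)c3cc(CN4CCCC4)sc3n2)o1` differs from compound 1 in several places. In this assay compound 2 gives 620 nM, a lower number beyond the scatter. Compound 3 `Nc1nc(-c2ccco2)nc2sc(CN3CCC(F)(F)CC3)cc12` carries 4,4-difluoropiperidin-1-yl in place of cyclohexylamino on a saturated chain carbon bound to an aromatic carbon. Going by the values given here, no single-point step covers this change, so the expectation rests loosely on compound 2 and is a modest move toward a lower number, expected as a 1.8-fold lower number from compound 1 to compound 3 (0.25 log units; within the scatter). Compound 3 is expected to give 1400 nM, within 450 nM to 4500 nM.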

Compound 3, inhibition constant: 2230 nM
The estimate for compound 3 lay 1.6-fold (0.20 log units) below the measured number; measured number inside the range.
By their numbers in this assay, from the lowest: compound 2; then compounds 3 and 1 (each within the scatter of the next).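

In this assay, the swap to 4,4-difluoropiperidin-1-yl on a saturated chain carbon bound to an aromatic carbon gives a 1.1-fold lower number from compound 1 to compound 3 (0.05 log units; within the scatter). At this position, therefore, replacing cyclohexylamino, with its hydrogen-bond donor, by a ring lacking one leaves the two compounds unseparated. Nothing measured on these groups bears on this result.

Open, from the compounds shown here alone, is how a morpholin-4-yl group or a plain primary amine on the same chain carbon would read. Also open, going by these compounds, is whether the lower number of compound 2 follows its ring amine or its furan methyl.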